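Aryl substituent exchange and cytotoxicity in the shared-core series

The source may report more compounds than this note shows. Statements on the series, on what has been measured and on what is new or still open speak of the compounds shown alone.

Measured compounds in an ADME assay on HCT-15 cells (Homo sapiens) for cytotoxicity, read by sulforhodamine B assay, with a stated time of 24 h; on this read-out higher numbers stand for lower toxicity in this test and lower numbers for higher toxicity in this test:
- compound 1 (`COc1ccc(C(=O)/C=C/c2cc3ccccc3[nH]c2=O)cc1`): a limit of > 100000 nM
- compound 2 (`O=C(/C=C/c1cc2ccccc2[nH]c1=O)c1ccc(O)cc1`): a limit of > 100000 nM

Going by the values given here, compound 2 stands only at a limit in this assay, and the one further value shown is a limit as well. Both values sit at the limit of > 100000 nM in this assay, at which 2 of the 2 values shown sit. Among the compounds with values here, the single measured step, a step that the two limits leave unreadable from compound 1 to compound 2, is therefore of unreadable size and gives no number to lean on.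

Compound 3 (`O=C(/C=C/c1cc2ccccc2[nH]c1=O)c1ccc(Cl)cc1`) differs from compound 2 by chloro in place of hydroxy on an aromatic carbon. No measured step covers an exchange of this kind on the aryl ketone ring, and the only step shown is blank between two limits. The expectation for compound 3 rests on the standing of compound 2 alone, which in this assay gives > 100000 nM. The step that the limit leaves unreadable from compound 2 to compound 3 is expected to be of no readable size. Compound 3 is thus estimated at 150000 nM, with a range from 30000 nM to 600000 nM. A limit rather than a number is the more likely outcome for compound 3.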

Compound 3, concentration lethal to 50% of the cells: > 100000 nM
Compound 3: a limit, no number; the forecaster's own chance of this, stated with the estimate: 70%; the middle value lies beyond the limit too.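

In this assay compound 3 gives > 100000 nM as a limit and not a number, so the steps to compound 3 from compound 1 and from compound 2 cannot be read. The compounds shown leave open how toxic compound 1, compound 2 and compound 3 are, and whether methoxy, hydroxy and chloro differ at all on this read-out.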